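Aryl amine swap on the shared core: compound 3

The source may hold more compounds than are shown below. What is called first, only, known or untested is meant among the compounds shown, and "the series" means these compounds.

Of the compounds shown here, two have been measured in a functional assay on MGC-803 cells (Homo sapiens) for inhibition, read by MTT assay, with a stated time of 72 h; on this read-out higher numbers stand for weaker inhibition and lower numbers for stronger inhibition. Compound 1 `COc1ccccc1Nc1nc(SCc2cn(Cc3ccccc3Cl)nn2)nc(-c2ccccc2)c1C#N` gives 5800 nM. Compound 2 `N#Cc1c(Nc2ccc(F)cc2)nc(SCc2cn(Cc3ccccc3Cl)nn2)nc1-c1ccccc1` gives 8740 nM. Compound 2 is not told apart from compound 1 on this read-out, since a 1.5-fold higher number from compound 1 to compound 2 (0.18 log units; within the scatter). Compound 3 `Cc1ccccc1Nc1nc(SCc2cn(Cc3ccccc3Cl)nn2)nc(-c2ccccc2)c1C#N` carries 2-methylphenyl in place of 4-fluorophenyl on a nitrogen on an aromatic ring, so its difference from compound 1 is only a methyl in place of a methoxy on the same ring. The one step that bears on this change is the swap from compound 1 to compound 2, which was within the scatter; a swap among these aryl groups on the amine nitrogen has so far moved the number little. For compound 3 no step beyond the scatter is therefore expected, with a 1.6-fold lower number from compound 2 to compound 3 (0.20 log units; within the scatter) as the estimated change. Compound 3 is expected to give about 5500 nM, within a range from 2500 nM to 12000 nM.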

Compound 3, half-maximal inhibitory concentration: 7280 nM
Compound 3: the middle estimate sits 1.3-fold (0.12 log units) below what was measured; the range from low to high includes it.
By their numbers in this assay, from the lowest: compounds 1, 3 and 2 (each within the scatter of the next).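

In this assay, the swap to 2-methylphenyl gives a 1.2-fold lower number from compound 2 to compound 3 (0.08 log units; within the scatter), and methyl in place of methoxy on the same aryl ring gives a 1.3-fold higher number from compound 1 to compound 3 (0.10 log units; within the scatter). The series now has three aryl groups on the amine nitrogen, all within the scatter of one another, so this read-out does not separate 2-methoxyphenyl, 2-methylphenyl and 4-fluorophenyl. The comparison of compound 1 with compound 3 adds a change confined to one ring substituent, and the oxygen of the methoxy group can give way to the carbon of a methyl group without a step beyond the scatter; no measurement on hand accounts for this.

The compounds shown leave open whether an amine or a carboxylic acid on this aryl ring would shift the number beyond the scatter. They also leave open whether a longer alkyl chain in place of the aryl group on the nitrogen would do so.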